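The compounds below may be only part of what the source reports. "The series", "measured", "known", "first", "only" and "open" are said of these compounds alone.

Three compounds have so far been measured in a functional assay on A549 cells (Homo sapiens) for inhibition, read by CCK-8 assay, with a stated time of 72 h, tested at 1 uM; on this read-out lower numbers stand for less inhibition of growth and higher numbers for more inhibition of growth at the one concentration tested:

Compound 1, `CN(C)C(=O)c1cc2cnc(Nc3ccc(NC(=O)C4(C(=O)Nc5ccccc5)CC4)cc3)nc2n1C1CCCC1`, gives 75%.
Compound 2, `CN(C)C(=O)c1cc2cnc(Nc3ccc(NC(=O)C4(C(=O)Nc5cccc(C(F)(F)F)c5)CC4)cc3)nc2n1C1CCCC1`, gives 15.7%.
Compound 3, `Cc1cccc(NC(=O)C2(C(=O)Nc3ccc(Nc4ncc5cc(C(=O)N(C)C)n(C6CCCC6)c5n4)cc3)CC2)c1`, gives 35.2%.

All three share one core and differ only in one group on one aromatic ring. Compound 3 stands second of the three numbers: above compound 2, well below compound 1, and beyond the scatter from both. Compound 4, `CN(C)C(=O)c1cc2cnc(Nc3ccc(NC(=O)C4(C(=O)Nc5cccc(C#N)c5)CC4)cc3)nc2n1C1CCCC1`, has not yet been measured. It differs from compound 3 in one place: cyano in place of methyl on an aromatic carbon.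

Going by the values given here, three measured steps bear on this change. Methyl in place of hydrogen on an aromatic carbon gave a number 39.8 percentage points lower from compound 1 to compound 3 (beyond the scatter), and trifluoromethyl in place of hydrogen gave a number 59.3 percentage points lower from compound 1 to compound 2 (beyond the scatter), so both groups tried at this position lowered growth inhibition compared with the unsubstituted ring of compound 1. Between the two groups, a number 19.5 percentage points higher from compound 2 to compound 3 (beyond the scatter). Among the compounds with values here, no measured step involves cyano, so its effect here is uncertain; as a third group at the same place, a number near that of compound 3, or somewhat lower, seems the likeliest outcome. Compound 4 is therefore estimated to give 30%, with a range from 10% to 55%, which corresponds to an expected a number 5.2 percentage points lower from compound 3 to compound 4 (within the scatter).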

Compound 4, percent growth inhibition at one concentration: 70.8%
Compound 4: middle estimate off by 40.8 percentage points, on the low side, and the stated range ends below it.
By their numbers in this assay, from the lowest: compound 2; then compound 3; then compounds 4 and 1 (each within the scatter of the next).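

In this assay, a substituent at this place on the ring does not by itself cost growth inhibition: cyano in place of hydrogen gives a number 4.2 percentage points lower from compound 1 to compound 4 (within the scatter) and leaves compound 4 level with the unsubstituted ring of compound 1. Going by these compounds alone, what the earlier compounds could not separate now becomes clear, since the drop seen with methyl and trifluoromethyl belongs to those two groups and not to substitution at this carbon as such: cyano in place of methyl gives a number 35.6 percentage points higher from compound 3 to compound 4 (beyond the scatter) and cyano in place of trifluoromethyl gives a number 55.1 percentage points higher from compound 2 to compound 4 (beyond the scatter) on the same shared core. Nothing available here accounts for why cyano parts from the other two groups.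

On these data alone, whether a methoxy group, an amine or a carboxylic acid at this carbon would stay with hydrogen and cyano or fall with methyl and trifluoromethyl remains open. Also open, as far as these compounds go, is whether cyano would hold up on other carbons of this ring, and how these compounds would compare at concentrations other than the single one tested.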